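The source may hold more compounds than are shown below. What is called first, only, known or untested is meant among the compounds shown, and "the series" means these compounds.

Of the compounds shown here, two of a shared core have been measured in a physicochemical assay, read by spectrophotometry, with a stated time of 10 min; on this read-out lower numbers stand for stronger inhibition and higher numbers for weaker inhibition. Compound 1 `O=c1cc(-c2ccccc2)oc2cc(OCCCCNc3nc4ccc([N+](=O)[O-])cc4s3)cc(O)c12` carries a nitro group on its benzothiazole ring and gives 8.14 ug/mL in this assay. Compound 2 `O=C(O)c1ccc2nc(NCCCCOc3cc(O)c4c(=O)cc(-c5ccccc5)oc4c3)sc2c1` differs only in that group: a 1.2-fold lower number from compound 1 to compound 2 (0.08 log units; within the scatter). Compound 2 thus stands with the lower of the two numbers, but its value of 6.74 ug/mL lies within the scatter of compound 1, so the two cannot be told apart.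

Compound 3 `O=c1cc(-c2ccccc2)oc2cc(OCCCCNNc3nc4ccccc4s3)cc(O)c12` is not yet measured. Relative to compound 2 it changes as follows: (1,3-benzothiazol-2-yl)amino in place of 6-carboxy-1,3-benzothiazol-2-yl on an amine nitrogen. For the measured compounds named here, the only measured step that bears on this, from compound 1 to compound 2, swapped one group on that same aromatic ring and produced nothing beyond the scatter. Nothing measured speaks to the added nitrogen in the linker, so the expectation rests on that single step alone.

Compound 3 is therefore expected to stay close to compound 2, at 7.5 ug/mL with a plausible range from 3.5 ug/mL to 16 ug/mL, a step of a 1.1-fold higher number from compound 2 to compound 3 (0.05 log units; within the scatter) that is expected to remain within the scatter.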

Compound 3, half-maximal inhibitory concentration: 8.73 ug/mL
Compound 3: middle estimate off by 1.2-fold (0.07 log units), on the low side; the range from low to high includes it.
By their numbers in this assay, from the lowest: compounds 2, 1 and 3 (each within the scatter of the next).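

In this assay putting (1,3-benzothiazol-2-yl)amino in place of 6-carboxy-1,3-benzothiazol-2-yl on the amine nitrogen gives a 1.3-fold higher number from compound 2 to compound 3 (0.11 log units; within the scatter) and, in place of 6-nitro-1,3-benzothiazol-2-yl, gives a 1.1-fold higher number from compound 1 to compound 3 (0.03 log units; within the scatter) on the same read-out. For the compounds shown here, the earlier pair showed only that one group on the ring could stand in for another, whereas this change brings a second nitrogen at the amine and carries neither carboxy nor nitro, and the three compounds still cannot be told apart. No measurement offered here explains this lack of separation.

Compound 3 differs from compound 1 and compound 2 both in the added nitrogen and in the missing ring group, so a compound with plain 1,3-benzothiazol-2-yl directly on the amine nitrogen would be needed to read those two changes apart. Going by these compounds, it also remains open whether an amine or an amide on the ring, or a longer chain on the amine nitrogen, would move the number beyond the scatter.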